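Swapping the Chloropyrazine Amide for a Methoxypyridine

A few compounds are considered here, and "the series" means these few. Any claim that something is new, unique, unknown or untested is made for them only; others in the source may bear on it.

Compound 2 `C[C@@H](NC(=O)C1(NC(=O)c2cncc(Cl)n2)CC1)c1ccc(-n2nc(Cl)c3ccccc32)cc1F` holds the higher of the two numbers in an in vivo ADME assay on the whole organism (strain Sprague-Dawley) for pharmacokinetics, with Rattus norvegicus as the target; a higher number here means faster removal of the compound, a lower number slower removal: compound 2 gives 105 mL/min/kg, while compound 1 `COc1ncc(C(=O)NC2(C(=O)N[C@H](C)c3ccc(-n4nc(Cl)c5ccccc54)cc3F)CC2)s1` gives 12.7 mL/min/kg. Among the compounds with values here, the single measured step, an 8.3-fold higher number from compound 1 to compound 2 (0.92 log units; beyond the scatter), is the only reference available. Compound 3 `COc1cncc(C(=O)NC2(C(=O)N[C@H](C)c3ccc(-n4nc(Cl)c5ccccc54)cc3F)CC2)c1` has not been measured; it differs from compound 2 by 5-methoxypyridin-3-yl in place of 6-chloropyrazin-2-yl on a carbonyl carbon. Within the data shown here, this removes the group whose arrival accompanied the rise from compound 1 to compound 2, and brings in a ring that, like the one in compound 1, carries a methoxy group. Because an 8.3-fold higher number from compound 1 to compound 2 (0.92 log units; beyond the scatter) went with the loss of a methoxy-substituted ring, a partial reversal appears the more likely outcome, though the entering ring is not the ring of compound 1, so a full return is not assumed. Compound 3 is therefore expected to give 30 mL/min/kg in this assay, within 12 mL/min/kg to 75 mL/min/kg. The expected step is a 3.5-fold lower number from compound 2 to compound 3 (0.54 log units; beyond the scatter).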

Compound 3, clearance: 7.8 mL/min/kg
The estimate for compound 3 lay 3.8-fold (0.59 log units) above the measured number, outside the stated range (below it).
By their numbers in this assay, from the lowest: compounds 3 and 1 (each within the scatter of the next); then compound 2.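

In this assay, 5-methoxypyridin-3-yl in place of 6-chloropyrazin-2-yl on the carbonyl carbon gives a 13-fold lower number from compound 2 to compound 3 (1.13 log units; beyond the scatter), so this position can carry a large step in either direction from compound 2. A second ring exchange at the same place, with 5-methoxypyridin-3-yl in place of 2-methoxy-1,3-thiazol-5-yl, gives a 1.6-fold lower number from compound 1 to compound 3 (0.21 log units; within the scatter), so among these three compounds the two methoxy-bearing rings stand together and only the 6-chloropyrazin-2-yl compound stands apart. No measurement here accounts for this difference in clearance.

The step from compound 2 to compound 3 alters the ring and its substituent at once, so the compounds shown cannot separate the two. On these data alone, it remains open how a pyrazine ring bearing a methoxy group, or a pyridine ring bearing a chlorine, would behave at this position.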